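This account rests on a few compounds, and the source may have more. Where it says the series, first, only, none or still open, it means among the compounds named here.

Measured compounds:

Compound 1 `CC(C)C(=O)Nc1ccc(S(=O)(=O)Oc2ccccc2I)cc1` — in a functional assay on MCF7 cells (Homo sapiens) for antiproliferative activity, read by sulforhodamine B assay, with a stated time of 48 h (a higher number here means a weaker inhibitor, a lower number a stronger inhibitor), compound 1 gives 8100 nM

Compound 2 `CC(C)c1ccccc1OS(=O)(=O)c1ccc(NC(=O)C(C)(C)C)cc1` — in this assay compound 2 gives 6500 nM

Compound 2 stands at one end of these two numbers and compound 1 at the other, but the gap between them lies within the scatter of the method, so the two compounds cannot be told apart on this evidence. Compound 3 `CC(C)(C)C(=O)Nc1ccc(S(=O)(=O)Oc2ccccc2I)cc1` has not yet been measured in this assay. It differs from compound 2 in one place: iodo in place of isopropyl on an aromatic carbon. Among the compounds with values here, no pair of measured compounds isolates this exchange, so its effect is not known directly. Compound 1 carries the same iodo group that enters in compound 3 and differs from compound 2 at another place, and its value in this assay stays within the scatter of compound 2, so no step beyond the scatter is expected. Compound 3 is estimated to give 7500 nM, with a range from 3000 nM to 19000 nM. This estimate corresponds to a step of a 1.2-fold higher number from compound 2 to compound 3 (0.06 log units; within the scatter), expected to be no larger than the scatter.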

Compound 3, half-maximal inhibitory concentration: 6600 nM
Compound 3: middle estimate off by 1.1-fold (0.06 log units), on the high side, within the range that was stated.
By their numbers in this assay, from the lowest: compounds 2, 3 and 1 (each within the scatter of the next).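

In this assay the exchange of isopropyl for iodo on this aromatic carbon, ortho to a large group, gives no change that can be read (a 1.0-fold higher number from compound 2 to compound 3 (0.01 log units; within the scatter)), so a single iodine atom and a three-carbon group cannot be told apart here. Within the data shown here, compound 3 also gives a first reading of methyl in place of hydrogen on the saturated chain carbon bound to a carbonyl carbon, and this step too stays within the scatter (a 1.2-fold lower number from compound 1 to compound 3 (0.09 log units; within the scatter)). Nothing available explains why neither exchange shifts the value.

With all three compounds this close, the shown data do not tell what could shift the value at either place. An amine or a carboxylic acid on this aromatic carbon, or a longer chain on that saturated chain carbon, remains an open case.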